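A methoxy for a methylsulfanyl: expecting little change

A few compounds are considered here, and "the series" means these few. Any claim that something is new, unique, unknown or untested is made for them only; others in the source may bear on it.

Compound 1 `CCc1cc(C(C)=O)c(O)cc1OCCCCCCC#N` and compound 2 `CSCc1cc(C(C)=O)c(O)cc1OCCCCCCC#N` share one core and differ only in the group on a saturated chain carbon bound to an aromatic carbon. In an assay on isolated protein for binding affinity to leukotriene B4 receptor 1 (Homo sapiens), tested at 1 uM (on this read-out lower numbers stand for less inhibition and higher numbers for more inhibition at the one concentration tested (going by the name of the read-out)), compound 1 gives 73% and compound 2 gives 64%. On paper compound 2 holds the lower of the two numbers, with compound 1 nearest, yet the step of a number 9 percentage points lower from compound 1 to compound 2 (within the scatter) lies within the scatter, so the two compounds are not told apart by this assay.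

Compound 3 `COCc1cc(C(C)=O)c(O)cc1OCCCCCCC#N` differs from compound 2 by methoxy in place of methylsulfanyl on a saturated chain carbon bound to an aromatic carbon. Within the data shown here, the only measured step that bears on this change is a number 9 percentage points lower from compound 1 to compound 2 (within the scatter), and it was within the scatter. Among the measured compounds shown here, with no other pair in hand, the expected step for compound 3 in this assay is a number 4 percentage points higher from compound 2 to compound 3 (within the scatter), that is none beyond the scatter, in either direction. Compound 3 is therefore estimated to give 68% in this assay, with the expected range running from 50% to 82%.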

Compound 3, a percentage reported as inhibition, at one concentration (the size of the read-out at that concentration, not a potency): 7%
Compound 3: the middle estimate sits 61 percentage points above what was measured, and the stated range ends above it.
By their numbers in this assay, from the lowest: compound 3; then compounds 2 and 1 (each within the scatter of the next).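

In this assay, the group on this saturated chain carbon bound to an aromatic carbon proves to matter far more than the earlier pair suggested: methyl and methylsulfanyl could not be told apart, whereas the change to methoxy brings a number 57 percentage points lower from compound 2 to compound 3 (beyond the scatter), and methoxy in place of methyl brings a number 66 percentage points lower from compound 1 to compound 3 (beyond the scatter) as well. Methylsulfanyl and methoxy have the same counts of heavy atoms, hydrogen-bond donors and acceptors and no net charge, and differ by an oxygen in place of a sulfur, so these counts alone do not separate two groups that this read-out separates clearly. Nothing measured here gives a reason for the gap.

The compounds shown leave open whether the low number belongs to methoxy alone or would also appear with a hydroxy group, an amine or an ethoxy group on this carbon. They also leave open whether the gap between methylsulfanyl and methoxy would persist if the chain ending in the nitrile were replaced by a shorter chain or one ending in a carboxylic acid.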